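The source may hold more compounds than are shown below. What is called first, only, known or untested is meant among the compounds shown, and "the series" means these compounds.

Three compounds share one core and differ only in the group on the outer aromatic ring. Compound 1 `CC(=O)Nc1ccc(NC(=O)c2cn(Cc3c(F)cccc3F)c3ccc(=O)[nH]c3c2=O)cc1` carries acetamido there; in an in vitro assay on Sf21 cells for inhibition of high affinity 3',5'-cyclic-AMP phosphodiesterase 7A (Homo sapiens), read by scintillation proximity assay, with a stated time of 30 min (a lower number here means a stronger inhibitor, a higher number a weaker inhibitor), compound 1 gives 24 nM. Compound 3 `CNC(=O)c1ccc(NC(=O)c2cn(Cc3c(F)cccc3F)c3ccc(=O)[nH]c3c2=O)cc1` carries methylcarbamoyl; in this assay compound 3 gives 29 nM. Compound 2 `O=C(O)Cc1ccc(NC(=O)c2cn(Cc3c(F)cccc3F)c3ccc(=O)[nH]c3c2=O)cc1` carries carboxymethyl, and in this assay compound 2 gives 176 nM. Among these three numbers compound 3 stands second highest, close to compound 1 and far from compound 2: a 1.2-fold higher number from compound 1 to compound 3 (0.08 log units; within the scatter), while a 6.1-fold lower number from compound 2 to compound 3 (0.78 log units; beyond the scatter). Compound 4 `NS(=O)(=O)c1ccc(NC(=O)c2cn(Cc3c(F)cccc3F)c3ccc(=O)[nH]c3c2=O)cc1` is not yet measured; it differs from compound 3 in one place: sulfamoyl in place of methylcarbamoyl on an aromatic carbon. Going by the values given here, no measured step brings in sulfamoyl, so the nearest guide is the pair of steps from compound 1, where a 1.2-fold higher number from compound 1 to compound 3 (0.08 log units; within the scatter) and a 7.3-fold higher number from compound 1 to compound 2 (0.87 log units; beyond the scatter): exchanging acetamido for methylcarbamoyl left the number within the scatter, whereas exchanging it for carboxymethyl raised it. Since sulfamoyl, like the groups it joins, carries no net charge, in this assay compound 4 is expected to land near compound 3, with a 1.4-fold higher number from compound 3 to compound 4 (0.14 log units; within the scatter) as the expected step. The estimate for compound 4 in this assay is 40 nM, within 15 nM to 110 nM.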

Compound 4, half-maximal inhibitory concentration: 34 nM
The estimate for compound 4 lay 1.2-fold (0.07 log units) above the measured number; the range from low to high includes it.
By their numbers in this assay, from the lowest: compounds 1, 3 and 4 (each within the scatter of the next); then compound 2.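

In this assay, this position, para to a large group, takes sulfamoyl as readily as methylcarbamoyl, even though sulfur replaces carbon and the count of hydrogen-bond acceptors rises: there is a 1.2-fold higher number from compound 3 to compound 4 (0.07 log units; within the scatter), and also a 1.4-fold higher number from compound 1 to compound 4 (0.15 log units; within the scatter), so compounds 1, 3 and 4 cannot be told apart here. Carboxymethyl now stands alone among the four groups, with a 5.2-fold lower number from compound 2 to compound 4 (0.71 log units; beyond the scatter). No measurement is available to explain why these groups match or why carboxymethyl differs.

From the compounds shown here alone, it remains open whether a carboxylic acid set directly on the ring, an amine, or a longer chain on the sulfamoyl nitrogen would track compound 2 or the other three. The compounds shown also cannot tell whether these groups would give similar numbers elsewhere on the outer ring.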